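This account rests on a few compounds, and the source may have more. Where it says the series, first, only, none or still open, it means among the compounds named here.

Compound 1 `O=C(/C=C/c1cc(Br)ccc1O)c1ccc(Br)cc1` and compound 2 `Cc1ccc(C(=O)/C=C/c2cc(Br)ccc2O)cc1` share one core, while compound 3 `N#CC1=C(N)Oc2ccc(Br)cc2C1CC(=O)c1ccc(Br)cc1` and compound 4 `Cc1ccc(C(=O)CC2C(C#N)=C(N)Oc3ccc(Br)cc32)cc1` share another; the difference between the two cores is not broken down here. In an ADME assay on MCF-10A cells (Homo sapiens) for cytotoxicity, read by sulforhodamine B assay, with a stated time of 72 h, tested at 10 uM (a higher number here means a stronger effect of the compound at the concentration tested, a lower number a weaker effect), compound 1 gives 32.8% and compound 2 gives 32.4%. The change between them, (methyl in place of bromo on an aromatic carbon), made a step of a number 0.4 percentage points lower from compound 1 to compound 2 (within the scatter). In this assay compound 3 gives 32.6%, close to the value of compound 1. Compound 4 carries the same change on its own core, (methyl in place of bromo on an aromatic carbon), at a place described in the same words. Because the earlier step of a number 0.4 percentage points lower from compound 1 to compound 2 (within the scatter) stayed within the scatter, the expected step here is a number 0.1 percentage points lower from compound 3 to compound 4 (within the scatter). Compound 4 is therefore estimated at 32.5%, with a likely range from 22% to 43%.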

Compound 4, a percentage reported as activity, at one concentration (the size of the read-out at that concentration, not a potency): 133%
The estimate for compound 4 lay 100.5 percentage points below the measured number; the measured number lies above the stated range.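

In this assay, putting methyl in place of bromo on the core of compound 3 gave a number 100.4 percentage points higher from compound 3 to compound 4 (beyond the scatter). The size of this step on one core therefore did not predict its size on the other, so the change cannot be carried between these two cores as a fixed step: the same change on two cores in this assay, a number 0.4 percentage points lower (within the scatter) from compound 1 to compound 2 and a number 100.4 percentage points higher (beyond the scatter) from compound 3 to compound 4, 100.8 percentage points apart, beyond the scatter of two such steps. Going by these compounds alone, with a single pair on each core, this shows only that the core matters to the outcome; it does not show which part of the core is responsible or why.

Going by these compounds, whether a large step would also appear with a chloro, methoxy or amine group in that place on the core of compound 3 stays open. So does whether such groups would leave the core of compound 1 as flat as methyl did.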